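The source may report more compounds than this note shows. Statements on the series, on what has been measured and on what is new or still open speak of the compounds shown alone.

Compound 1 `C=CCN(CC=C)CC(=O)N1N=C(C)CC1c1cc(Br)ccc1O` gives 3090 nM in a functional assay on PC-3 cells (Homo sapiens) for cytotoxicity, read by MTT assay, with a stated time of 48 h; a higher number here means a weaker inhibitor, a lower number a stronger inhibitor. Compound 2 `CC(=O)Oc1ccccc1C1CC(C)=NN1C(=O)CN(C(C)C)C(C)C` gives 24500 nM. Compound 3 `O=C(CCl)N1N=C(c2cc3ccccc3oc2=O)CC1c1ccccc1` gives 2980 nM.

Compound 3 has the lowest number of the three, but its gap to compound 1 lies within the scatter, so the two cannot be ordered; compound 2 stands beyond the scatter with the higher number. Compound 4 `CC1CCCCN1CC(=O)N1N=C(c2cc3ccccc3oc2=O)CC1c1ccccc1` differs from compound 3 in one place: 2-methylpiperidin-1-yl in place of chloro on a saturated chain carbon bound to a carbonyl carbon. Among the measured compounds shown here, no measured pair shows this change, and no measured compound carries the 2-methylpiperidin-1-yl group, so its effect is unknown here. A small step toward a higher number, not clearly beyond the scatter, is expected, a 1.7-fold higher number from compound 3 to compound 4 (0.22 log units; within the scatter). Compound 4 is therefore estimated at 5000 nM, with a range from 1500 nM to 16000 nM.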

Compound 4, half-maximal inhibitory concentration: 36300 nM
Beside the measured number, compound 4's estimate is 7.3-fold (0.86 log units) below it; the whole stated range lies below it.
By their numbers in this assay, from the lowest: compounds 3 and 1 (each within the scatter of the next); then compounds 2 and 4 (each within the scatter of the next).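

On the saturated chain carbon bound to a carbonyl carbon, replacing chloro with 2-methylpiperidin-1-yl in this assay gives a 12-fold higher number from compound 3 to compound 4 (1.09 log units; beyond the scatter) and shows that this position is sensitive to the group it carries. The step is large and lies beyond the scatter, so the change gives a clearly weaker inhibitor. Nothing available here explains why the number rises.

Among the compounds shown here, the single step cannot separate the effect of losing chloro from that of adding the ring or its methyl. A plain piperidin-1-yl or a morpholin-4-yl group at this position would help to tell these apart.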